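Hydroxypyrrolidine for carboxyazetidine: expected antiproliferative step

A few compounds are considered here, and "the series" means these few. Any claim that something is new, unique, unknown or untested is made for them only; others in the source may bear on it.

In a functional assay on HeLa cells (Homo sapiens) for antiproliferative activity, read by CCK-8 assay, with a stated time of 48 h (a higher number here means a weaker inhibitor, a lower number a stronger inhibitor), compound 3 `COc1ccc(/C=C\c2cc(OC)c(OC)c(OC)c2)cc1OCc1ccc(CN2CC(C(=O)O)C2)cc1` gives 6500 nM. Compound 2 `COc1ccc(/C=C\c2cc(OC)c(OC)c(OC)c2)cc1OCc1ccc(CNCCO)cc1` gives 4400 nM, within the scatter of compound 3. Compound 1 `COc1ccc(/C=C\c2cc(OC)c(OC)c(OC)c2)cc1OCc1ccc(CN[C@H](C(=O)O)[C@H](C)O)cc1` reaches only a limit of the assay, > 10000 nM.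

Compound 4 `COc1ccc(/C=C\c2cc(OC)c(OC)c(OC)c2)cc1OCc1ccc(CN2CC[C@@H](O)C2)cc1` differs from compound 3 by 3-hydroxypyrrolidin-1-yl in place of 3-carboxyazetidin-1-yl on a saturated chain carbon bound to an aromatic carbon.

Going by the values given here, no measured step makes this exact change. The closest evidence is a 1.5-fold higher number from compound 2 to compound 3 (0.17 log units; within the scatter), with 3-carboxyazetidin-1-yl in place of (2-hydroxyethyl)amino. Also relevant is an at least 2.2-fold lower number from compound 1 to compound 2 (0.35 log units; beyond the scatter), with 2-hydroxyethyl in place of 1-carboxy-2-hydroxypropyl on an amine nitrogen. These two steps suggest, at most, a small shift toward a lower number in this assay on leaving the carboxy-bearing group.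

The expected step is a 1.9-fold lower number from compound 3 to compound 4 (0.27 log units; within the scatter), which is not expected to exceed the scatter. For compound 4 the estimated value is 3500 nM, with an expected range of 1300 nM to 9000 nM.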

Compound 4, half-maximal inhibitory concentration: > 10000 nM
Compound 4: only a limit was reported (the forecaster's own chance of this, stated with the estimate: 12%); at least 2.8-fold (0.45 log units) between middle value and limit.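

The change to 3-hydroxypyrrolidin-1-yl gives an at least 1.5-fold higher number from compound 3 to compound 4 (0.18 log units; that floor lies within the scatter), so at this position on the saturated chain carbon bound to an aromatic carbon, the expected gain on leaving 3-carboxyazetidin-1-yl does not appear. The firmer comparison is an at least 2.2-fold higher number from compound 2 to compound 4 (0.35 log units; beyond the scatter): neither compound carries a carboxy group, so its absence alone does not set the read-out in this assay, and the group on the amine nitrogen still matters. The step from compound 1 to compound 4 cannot be read, and both compounds sit at the same limit: the limit of > 10000 nM in this assay, at which 2 of the 4 values shown sit.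

Open, from the compounds shown here alone, is whether a carboxylic acid on the five-membered ring, in place of the hydroxy group, would read differently from compound 4, which would separate ring size from the group the ring carries. Also open, going by these compounds, are the other configuration at the defined stereocentre of compound 4 and the effect of a longer chain on the amine nitrogen of compound 2.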